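Pyridin-3-yl in place of thiophen-3-yl

A few compounds are considered here, and "the series" means these few. Any claim that something is new, unique, unknown or untested is made for them only; others in the source may bear on it.

In a functional assay on MDA-MB-231 cells (Homo sapiens) for cytotoxicity, read by ELISA, with a stated time of 2 days (on this read-out higher numbers stand for weaker inhibition and lower numbers for stronger inhibition), compound 1 (`Oc1ccc(-c2cc(-c3ccccc3)cc(-c3cccs3)n2)cc1`) gives 2400 nM and compound 2 (`Oc1ccc(-c2cc(-c3ccccc3)cc(-c3ccsc3)n2)cc1`) gives 5700 nM as the higher of the two numbers. Compound 3 (`Oc1ccc(-c2cc(-c3ccccc3)cc(-c3cccnc3)n2)cc1`) carries pyridin-3-yl in place of thiophen-3-yl on an aromatic carbon. For the measured compounds named here, only one measured step bears on this change: thiophen-3-yl in place of thiophen-2-yl on the same carbon (a 2.4-fold higher number from compound 1 to compound 2 (0.38 log units; beyond the scatter)), which is modest but beyond the scatter. Going by the values given here, both measured compounds carry a five-membered aromatic ring there, so the data hold no direct example of a six-membered one. The step expected in this assay is therefore no larger than that modest one, with its direction unsettled and a slight lean towards a lower number. The estimated step is small (a 1.4-fold lower number from compound 2 to compound 3 (0.15 log units; within the scatter)). The expected value for compound 3 is 4000 nM within an estimated range of 1500 nM to 11000 nM in this read-out.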

Compound 3, half-maximal inhibitory concentration: 2200 nM
Beside the measured number, compound 3's estimate is 1.8-fold (0.26 log units) above it, within the range that was stated.
By their numbers in this assay, from the lowest: compounds 3 and 1 (each within the scatter of the next); then compound 2.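

In this assay, a six-membered aromatic ring at this position, next to the ring nitrogen, is accommodated: pyridin-3-yl improves on thiophen-3-yl (a 2.6-fold lower number from compound 2 to compound 3 (0.41 log units; beyond the scatter)) and does not separate from thiophen-2-yl (a 1.1-fold lower number from compound 1 to compound 3 (0.04 log units; within the scatter)). Ring size alone therefore does not set the number here, since the two five-membered rings differ from each other while the six-membered ring matches one of them, leaving compound 2 as the one that stands apart. Nothing at hand accounts for these differences.

Open, as far as these compounds go, is whether pyridin-4-yl would behave as pyridin-3-yl does, and whether a non-aromatic group such as an amine or a carboxylic acid would be accepted at this carbon. Also open, from the compounds shown here alone, is whether these steps would hold with the 4-hydroxyphenyl group or the phenyl group replaced.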